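Iodo step on the methoxy compound of a small series

The source may report more compounds than this note shows. Statements on the series, on what has been measured and on what is new or still open speak of the compounds shown alone.

Measured so far in a functional assay on MCF7 cells (Homo sapiens) for inhibition; on this read-out lower numbers stand for stronger inhibition and higher numbers for weaker inhibition:
- compound 1 (`Oc1ccc(-c2nc3cc(F)ccc3s2)cc1`) gives 400 nM
- compound 2 (`Oc1ccc(-c2nc3ccc(Br)cc3s2)cc1`) gives 4160 nM
- compound 3 (`COc1ccc(-c2nc3cc(F)ccc3s2)cc1`) gives 490 nM

Compound 3 (490 nM) lies within the scatter of compound 1 and well under compound 2 (4160 nM). Compound 4 (`COc1ccc(-c2nc3cc(F)ccc3s2)cc1I`) is still unmeasured. It differs from compound 3 by iodo in place of hydrogen on an aromatic carbon, ortho to a methoxy group (iodo in place of hydrogen on an aromatic carbon).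

Among the compounds with values here, the only measured step touching that methoxy group is at its oxygen (a 1.2-fold higher number from compound 1 to compound 3 (0.09 log units; within the scatter)), and it stays within the scatter. Within the data shown here, no iodo step has been measured, so this offers only weak guidance. With that single step as the guide, the expected change in this assay is none beyond the scatter (a 1.2-fold higher number from compound 3 to compound 4 (0.09 log units; within the scatter)), with wide uncertainty. The estimate for compound 4 is 600 nM (expected range 150 nM to 2500 nM).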

Compound 4, half-maximal inhibitory concentration: 820 nM
Beside the measured number, compound 4's estimate is 1.4-fold (0.14 log units) below it; the range from low to high includes it.
By their numbers in this assay, from the lowest: compounds 1, 3 and 4 (each within the scatter of the next, the first and the last beyond it); then compound 2.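

In this assay this carbon of the methoxy-bearing ring now has a reading with a substituent on it: iodo in place of hydrogen, ortho to a methoxy group, stays within the scatter (a 1.7-fold higher number from compound 3 to compound 4 (0.22 log units; within the scatter)). The earlier compounds shown here all carry hydrogen here, so they gave no information on this position, whereas compound 4 shows that a single iodine atom at this carbon is tolerated on the methoxy compound without a change beyond the scatter. Nothing available bears on why the step is this small.

Going by these compounds, one iodo step cannot define a trend at this carbon, so it remains open whether a smaller halogen such as chloro, an amine or a carboxylic acid would be tolerated here in the same way. On these data alone, it is also open whether iodo at this carbon would give a similar step on the hydroxy compound 1.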